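A few compounds are considered here, and "the series" means these few. Any claim that something is new, unique, unknown or untested is made for them only; others in the source may bear on it.

In a functional assay on MT4 cells (Homo sapiens) for inhibition (a higher number here means a weaker inhibitor, a lower number a stronger inhibitor), three compounds with a shared core have been measured. Compound 1 `C/C(=C\COC(=O)Nc1ccccc1)C1=CC(=O)C(C)(C)O1` gives 103 ug/mL, compound 2 `C/C(=C\COC(=O)NC(C)C)C1=CC(=O)C(C)(C)O1` gives 2.3 ug/mL, and compound 3 `C=CCNC(=O)OC/C=C(\C)C1=CC(=O)C(C)(C)O1` gives 2.8 ug/mL. Compound 3 cannot be told apart from compound 2, as a 1.2-fold higher number from compound 2 to compound 3 (0.09 log units; within the scatter) shows, while compound 1 lies far from both. Compound 4 `C/C(=C\COC(=O)NCc1ccccc1)C1=CC(=O)C(C)(C)O1` differs from compound 3 by one change: phenyl in place of vinyl on a saturated chain carbon bound to an amide-type nitrogen. This is phenyl in place of vinyl, or allyl to benzyl. Phenyl directly on the amide-type nitrogen went with much weaker inhibition, seen in a 45-fold lower number from compound 1 to compound 2 (1.65 log units; beyond the scatter) and a 37-fold lower number from compound 1 to compound 3 (1.57 log units; beyond the scatter). In compound 4, phenyl stands instead on a saturated chain carbon bound to an amide-type nitrogen, so only a small share of those large steps seems likely. A modest step is expected in this assay: a 2.1-fold higher number from compound 3 to compound 4 (0.33 log units; beyond the scatter). The estimate for compound 4 is 6 ug/mL, within a range of 1.5 ug/mL to 30 ug/mL.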

Compound 4, half-maximal inhibitory concentration: 2 ug/mL
Compound 4: the middle estimate sits 3.0-fold (0.48 log units) above what was measured; the measured number falls inside the stated range.
By their numbers in this assay, from the lowest: compounds 4, 2 and 3 (each within the scatter of the next); then compound 1.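

In this assay, phenyl in place of vinyl on a saturated chain carbon bound to an amide-type nitrogen changes nothing beyond the scatter (a 1.4-fold lower number from compound 3 to compound 4 (0.15 log units; within the scatter)), and neither does benzyl in place of isopropyl (a 1.2-fold lower number from compound 2 to compound 4 (0.06 log units; within the scatter)). A phenyl ring is therefore compatible with inhibition at this position when it sits on that saturated carbon, whereas benzyl in place of phenyl directly on the nitrogen gives a large step (a 52-fold lower number from compound 1 to compound 4 (1.71 log units; beyond the scatter)). On these data alone, whether a longer chain carrying the phenyl, or an amine or carboxylic acid on it, would behave like benzyl remains open. No evidence is available to explain the gap between benzyl and phenyl directly on the nitrogen.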